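The source may hold more compounds than are shown below. What is called first, only, known or untested is meant among the compounds shown, and "the series" means these compounds.

In a functional assay on HeLa cells (Homo sapiens) for antiproliferative activity, read by cell counting, with a stated time of 72 h (on this read-out higher numbers stand for weaker inhibition and lower numbers for stronger inhibition), compound 1 (`C#C[C@@]1(O)[C@@H](CO)O[C@@H](n2cnc3c(-c4ccccc4)ncnc32)[C@@H]1O`) gives > 250000 nM as a limit of the assay and not a number. Within the data shown here, compound 2 (`C#C[C@@]1(O)[C@@H](CO)O[C@@H](n2cc(Br)c3c(N)ncnc32)[C@@H]1O`) gives 93 nM and so holds the only true number so far. Compound 3 (`C#Cc1cn([C@@H]2O[C@H](CO)[C@](O)(C#C)[C@H]2O)c2ncnc(N)c12`) has ethynyl in place of bromo on an aromatic carbon and is still unmeasured. Among the measured compounds shown here, no measured pair shows what this swap does, so only a modest weakening in this assay is expected, and the estimated shift is a 2.2-fold higher number from compound 2 to compound 3 (0.33 log units; beyond the scatter) with real doubt about its direction. Compound 3 is estimated at 200 nM with an expected range from 30 nM to 1500 nM in this test.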

Compound 3, half-maximal inhibitory concentration: 114000 nM
Beside the measured number, compound 3's estimate is 570-fold (2.76 log units) below it, and the stated range ends below it.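

At this position, on an aromatic carbon of the five-membered ring, replacing bromo with ethynyl is far from a neutral swap: in this assay it gives a 1200-fold higher number from compound 2 to compound 3 (3.09 log units; beyond the scatter). A single place on the shared core can therefore separate strong inhibition from very weak inhibition. The step can be read in full, as only compound 1 rests at the end of the assay's range: the limit of > 250000 nM in this assay, at which 1 of the 3 values shown sits.

Still open, from the compounds shown here alone, is whether other small groups here, such as chloro, methyl or a nitrile, would keep the activity of bromo or lose it like ethynyl. The reason for the loss also remains unknown.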